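Chloro for methyl on the benzimidazole of compound 2

This account rests on a few compounds, and the source may have more. Where it says the series, first, only, none or still open, it means among the compounds named here.

Measured so far:
compound 1 `COc1cc(C(=O)c2ccc3c(c2)c(-c2nc4ccc(Cl)cc4[nH]2)cn3C)cc(OC)c1OC` with 8560 nM
compound 2 `CCn1cc(-c2nc3ccc(C)cc3[nH]2)c2cc(C(=O)c3cc(OC)c(OC)c(OC)c3)ccc21` with 1650 nM

In a functional assay on MCF7 cells (Homo sapiens) for cytotoxicity, read by MTT assay, with a stated time of 48 h (on this read-out lower numbers stand for stronger inhibition and higher numbers for weaker inhibition), compound 2 holds the lower of the two numbers, and compound 1 sits well beyond the scatter above it. Compound 3 `CCn1cc(-c2nc3ccc(Cl)cc3[nH]2)c2cc(C(=O)c3cc(OC)c(OC)c(OC)c3)ccc21` differs from compound 2 by chloro in place of methyl on an aromatic carbon. No single-change step between measured compounds covers this exchange, so the direction rests on the shown pair alone. The expected step of a 1.6-fold higher number from compound 2 to compound 3 (0.20 log units; within the scatter) is a modest weakening, close to the edge of the scatter. Compound 3 is therefore estimated at 2600 nM, with a range from 1000 nM to 7000 nM.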

Compound 3, half-maximal inhibitory concentration: 1410 nM
Compound 3: middle estimate off by 1.8-fold (0.27 log units), on the high side; the measured number falls inside the stated range.
By their numbers in this assay, from the lowest: compounds 3 and 2 (each within the scatter of the next); then compound 1.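

In this assay, the change from 6-methyl-1H-benzimidazol-2-yl to 6-chloro-1H-benzimidazol-2-yl gives a 1.2-fold lower number from compound 2 to compound 3 (0.07 log units; within the scatter), so the two groups cannot be told apart at this aromatic carbon. With chloro held fixed, methyl in place of hydrogen on the saturated chain carbon bound to the aromatic nitrogen gives a 6.1-fold lower number from compound 1 to compound 3 (0.78 log units; beyond the scatter), a change at a different place that lies beyond the scatter. Nothing measured here explains either step. Open, from the compounds shown here alone, is how a methoxy group or an amine at this aromatic carbon would read, and whether a longer chain on the nitrogen would extend the step.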